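The source may report more compounds than this note shows. Statements on the series, on what has been measured and on what is new or still open speak of the compounds shown alone.

Working notes on the series. Compound 1 `CC(=O)N1N=C(c2ccc(Cl)cc2)CC1c1cn(-c2ccccc2)nc1-c1ccc(Cl)c(Cl)c1` carries an acetyl on the ring nitrogen of the shared core; in a functional assay on the whole organism (strain Wistar) for inhibition, with Rattus norvegicus as the target, read by paw edema, with a stated time of 30 min, at a dose of 50 mg/kg by the oral route (a lower number here means less inhibition, a higher number more inhibition at the dose given (going by the name of the read-out)), compound 1 gives 45.7%. For the measured compounds named here, compound 2 `Clc1ccc(C2=NNC(c3cn(-c4ccccc4)nc3-c3ccc(Cl)c(Cl)c3)C2)cc1` has hydrogen in that place, and in this assay compound 2 gives 33%, the lowest of the two numbers so far; the only step measured is a number 12.7 percentage points lower from compound 1 to compound 2 (beyond the scatter), a modest fall beyond the scatter.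

Compound 3 `Clc1ccc(C2=NN(c3ccccc3)C(c3cn(-c4ccccc4)nc3-c3ccc(Cl)c(Cl)c3)C2)cc1` differs from compound 2 by phenyl in place of hydrogen on an amine nitrogen in a ring. Going by the values given here, the one step that bears on this change is the substitution at the same ring nitrogen, a number 12.7 percentage points lower from compound 1 to compound 2 (beyond the scatter), where a group on that nitrogen went with the higher number and bare hydrogen with the lower. Phenyl is not acetyl, so the size of the effect is not fixed by that step, but the direction it suggests is upward, and a step of similar, modest size is expected.

Compound 3 is therefore expected to give about 44% in this assay, within 30% to 58%, an expected step of a number 11 percentage points higher from compound 2 to compound 3 (beyond the scatter).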

Compound 3, a percentage reported as inhibition, in the whole organism at one dose (the size of the read-out at that dose, not a potency): 45.7%
The estimate for compound 3 lay 1.7 percentage points below the measured number, within the range that was stated.
By their numbers in this assay, from the lowest: compound 2; then compounds 1 and 3 (each within the scatter of the next).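

In this assay, the step of a number 12.7 percentage points higher from compound 2 to compound 3 (beyond the scatter) shows that the higher number on this amine nitrogen in a ring is not confined to acetyl: a second, quite different group goes with it as well. The exchange of one group for the other gives no change at the digits printed from compound 1 to compound 3 (within the scatter), so among the compounds shown, acetyl and phenyl cannot be told apart at this position, and the carbonyl of acetyl is not required for the number that compound 1 and compound 3 share. Across these three compounds, the only difference resolved at this position is between hydrogen and a group, and no measurement at hand gives a reason for it.

From the compounds shown here alone, it remains open whether a group as small as methyl, a longer chain or a phenyl carrying a carboxylic acid on this nitrogen would stay level with compound 1 and compound 3 or fall back towards compound 2. The read-out gives the size of the effect at one dose, so the matching numbers of compound 1 and compound 3 leave their relative potency unsettled.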